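This account rests on a few compounds, and the source may have more. Where it says the series, first, only, none or still open, it means among the compounds named here.

Compound 1 `O=C1NNC(=O)C2(CSC3=C2C(=O)c2ncccc2C3=O)N1` gives 5000 nM in a functional assay on XF498 cells (Homo sapiens) for antiproliferative activity, read by MTT assay, with a stated time of 96 h; a higher number here means a weaker inhibitor, a lower number a stronger inhibitor. Compound 2 `O=C1C2=C(C(=O)c3ncccc31)C1(CS2)NC(=O)N(c2ccc([N+](=O)[O-])cc2)C1=O` gives 1030 nM in this assay, the lower of the two numbers, and the gap to compound 1 lies beyond the usual scatter of repeated measurements. Compound 3 `CC(C)(C)c1ccc(N2C(=O)NC3(CSC4=C3C(=O)c3ncccc3C4=O)C2=O)cc1` differs from compound 2 in one place: tert-butyl in place of nitro on an aromatic carbon. Among the measured compounds shown here, no measured pair shows this change, so only a small step is expected, a 1.5-fold higher number from compound 2 to compound 3 (0.16 log units; within the scatter), within the scatter and in no firm direction. Compound 3 is therefore expected to give about 1500 nM in this assay, within a range from 500 nM to 5000 nM.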

Compound 3, half-maximal inhibitory concentration: 850 nM
Beside the measured number, compound 3's estimate is 1.8-fold (0.25 log units) above it, within the range that was stated.
By their numbers in this assay, from the lowest: compounds 3 and 2 (each within the scatter of the next); then compound 1.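

In this assay, the change from 4-nitrophenyl to 4-(tert-butyl)phenyl is a 1.2-fold lower number from compound 2 to compound 3 (0.08 log units; within the scatter) and leaves the two compounds unranked. At this ring carbon, then, a nitro group with hydrogen-bond acceptors and a tert-butyl group of carbon only give numbers that cannot be told apart. No measurement in hand accounts for this result. Going by these compounds, what an amine or a carboxylic acid on the same ring carbon would give remains open. A plain hydrogen there is also an open case, and it would show whether either group matters at all.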